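Swapping the aryl group on the triazole of an inactive core

A few compounds are considered here, and "the series" means these few. Any claim that something is new, unique, unknown or untested is made for them only; others in the source may bear on it.

Compound 1, with structure `N#CC1=C(N)Oc2c(N)cc3nc4ccccc4nc3c2C12C(=O)N(Cc1cnnn1-c1ccc([N+](=O)[O-])cc1)c1ccccc12`, carries a 4-nitrophenyl on a triazole nitrogen. In a functional assay on HCT-116 cells (Homo sapiens) for antiproliferative activity, read by MTT assay, with a stated time of 48 h (on this read-out lower numbers stand for stronger inhibition and higher numbers for weaker inhibition), compound 1 reaches only the assay limit of > 50000 nM. Compound 2, with structure `N#CC1=C(N)Oc2c(N)cc3nc4ccccc4nc3c2C12C(=O)N(Cc1cnnn1-c1cc(Cl)ccc1Cl)c1ccccc12`, bears a 2,5-dichlorophenyl at the same position. In this assay compound 2 likewise stops at the limit of > 50000 nM. The step that the two limits leave unreadable from compound 1 to compound 2 is therefore not readable, and both values sit at the same limit (the limit of > 50000 nM in this assay, at which 2 of the 2 values shown sit). Compound 3, with structure `COc1cc(-n2nncc2CN2C(=O)C3(C(C#N)=C(N)Oc4c(N)cc5nc6ccccc6nc5c43)c3ccccc32)c(OC)cc1Cl`, differs from compound 2 by 4-chloro-2,5-dimethoxyphenyl in place of 2,5-dichlorophenyl on an aromatic nitrogen. Among the measured compounds shown here, no measured step bears on this change in a readable way, since both neighbours stand at the limit. Given that compound 2 shows only the limit > 50000 nM, compound 3 is expected to stay weak, with an estimated step that the limit leaves unreadable from compound 2 to compound 3 and an expected value of 60000 nM, likely between 15000 nM and 200000 nM.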

Compound 3, half-maximal inhibitory concentration: > 50000 nM
Compound 3 was reported as a limit; the forecaster's own chance of this, stated with the estimate: 80%; the middle value does not contradict the limit.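

Compound 3, like compound 1 and compound 2, stops at an assay limit, so no step among these three compounds can be read: the limit of > 50000 nM in this assay, at which 3 of the 3 values shown sit. In this assay the compounds shown leave open whether any aryl group on the triazole of this shared core gives a measurable value.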